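Methyl on the Fused Ring: Outlook for Compound 4

The source may hold more compounds than are shown below. What is called first, only, known or untested is meant among the compounds shown, and "the series" means these compounds.

Values so far in a functional assay on A549 cells (Homo sapiens) for cytotoxicity, read by sulforhodamine B assay; on this read-out higher numbers stand for weaker inhibition and lower numbers for stronger inhibition:
compound 1 `COc1ccc(Cn2c3c(c4ccccc4c2=O)CCOc2ccccc2-3)cc1` gives 11000 nM.
compound 2 `COc1ccc(Cn2c3c(c4cc(C)ccc4c2=O)CCOc2ccccc2-3)cc1` gives > 100000 nM, a limit of the assay and not a number.
compound 3 `COCOc1ccccc1-c1cc2ccccc2c(=O)n1C` gives > 100000 nM, likewise a limit of the assay and not a number.

Compound 4 `COCOc1ccccc1-c1cc2cc(C)ccc2c(=O)n1C` remains to be measured. It differs from compound 3 by methyl in place of hydrogen on an aromatic carbon. The same kind of change separates compound 1 from compound 2, (methyl in place of hydrogen on an aromatic carbon), with the ring there part of a fused or bridged system of four rings rather than two; in this assay that step gave an at least 9.0-fold higher number from compound 1 to compound 2 (0.95 log units; beyond the scatter). How the core of compound 1 and the core of compound 3 differ is not broken down here. Two of the three values rest at the limit of > 100000 nM in this assay, at which 2 of the 3 values shown sit.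

With an at least 9.0-fold higher number from compound 1 to compound 2 (0.95 log units; beyond the scatter) running toward higher numbers, compound 4 is expected to stay at the limit, an estimated step that the limit leaves unreadable from compound 3 to compound 4. The estimate for compound 4 is 150000 nM, spanning 60000 nM to 600000 nM.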

Compound 4, half-maximal inhibitory concentration: 99800 nM
Compound 4: middle estimate off by 1.5-fold (0.18 log units), on the high side; measured number inside the range.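

In this assay, methyl in place of hydrogen on an aromatic carbon gave a number no higher from compound 3 to compound 4 (the limit leaves the size open), so the step does not carry over unchanged between these two cores: the same change on two cores in this assay, an at least 9.0-fold higher number (0.95 log units; beyond the scatter) from compound 1 to compound 2 and a number no higher (the limit leaves the size open) from compound 3 to compound 4, at least 9.1-fold (0.95 log units) apart, beyond the scatter of two such steps Compound 3 sits at > 100000 nM, a limit of the assay and not a number. Among these compounds, the pair shows only that the number did not rise on this core; it does not give the size of the step, and two cores cannot show which feature of them sets the difference or how a third core would respond.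

Still open, on these data alone, is whether an amine or a carboxylic acid on the same aromatic carbon would move the number on either core. Also open, as far as these compounds go, is whether a longer chain there would behave as methyl does.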